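Series notes: the side group on the chain carbon

The source may report more compounds than this note shows. Statements on the series, on what has been measured and on what is new or still open speak of the compounds shown alone.

Compound 3 `CC(C)C(Nc1nccs1)c1ccc(-c2ccc3cccc(F)c3c2)[nH]c1=O` stands lowest in a functional assay on CHO cells for antagonist activity at prostaglandin E2 receptor EP3 subtype (Homo sapiens), read by cAMP accumulation (a higher number here means a weaker inhibitor, a lower number a stronger inhibitor), at 10 nM, while compound 2 `CC(C)C(c1nnc[nH]1)c1ccc(-c2ccc3cccc(F)c3c2)[nH]c1=O` gives 21 nM and compound 1 `CC(C)C(c1ccc(-c2ccc3cccc(F)c3c2)[nH]c1=O)N1CCCCS1(=O)=O` gives 122 nM. Compound 4 `CC(C)C(/C=C1/CCNC1=O)c1ccc(-c2ccc3cccc(F)c3c2)[nH]c1=O` carries a group of 7 heavy atoms (5 carbon, 1 nitrogen, 1 oxygen; one five-membered non-aromatic ring with 1 hetero atom) in place of a group of 6 heavy atoms (3 carbon, 2 nitrogen, 1 sulfur; one five-membered aromatic ring with 2 hetero atoms), on a saturated chain carbon bound to an aromatic carbon and a saturated chain carbon. For the measured compounds named here, the steps that bear on this position are a 12-fold lower number from compound 1 to compound 3 (1.09 log units; beyond the scatter), a 2.1-fold lower number from compound 2 to compound 3 (0.32 log units; beyond the scatter) and a 5.8-fold lower number from compound 1 to compound 2 (0.76 log units; beyond the scatter): both five-membered aromatic groups gave lower numbers than the six-membered non-aromatic ring of compound 1, and the thiazolylamino of compound 3 gave a lower number than the triazolyl of compound 2. Compound 4 brings a non-aromatic ring with one hetero atom back, so a modest rise in this assay is expected, a 3.0-fold higher number from compound 3 to compound 4 (0.48 log units; beyond the scatter). Compound 4 is therefore estimated at 30 nM, with a range of 8 nM to 120 nM.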

Compound 4, half-maximal inhibitory concentration: 8.1 nM
The estimate for compound 4 lay 3.7-fold (0.57 log units) above the measured number, within the range that was stated.
By their numbers in this assay, from the lowest: compounds 4 and 3 (each within the scatter of the next); then compound 2; then compound 1.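

In this assay, a non-aromatic ring with one hetero atom on the chain carbon sits level with (1,3-thiazol-2-yl)amino (a 1.2-fold lower number from compound 3 to compound 4 (0.09 log units; within the scatter)), so a number this low does not need an aromatic ring at this place. The same group also gives lower numbers than the 4H-1,2,4-triazol-3-yl group (a 2.6-fold lower number from compound 2 to compound 4 (0.41 log units; beyond the scatter)) and the six-membered non-aromatic ring (a 15-fold lower number from compound 1 to compound 4 (1.18 log units; beyond the scatter)), so among these four compounds, aromatic against non-aromatic does not set the order. Going by these compounds, how a carboxylic acid or a simple open-chain amine would read at this place stays open. Nothing available explains these steps.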